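Varying the group on the carbonyl-bound oxygen

This account rests on a few compounds, and the source may have more. Where it says the series, first, only, none or still open, it means among the compounds named here.

Among the measured compounds shown here, compound 2 `COC(=O)C1=C(C)NC(C)=C(C(=O)OCc2ccc(OC)c(OC)c2)C1c1cccc([N+](=O)[O-])c1` gives 117 nM in a functional assay on HEK293 cells for antagonist activity at Voltage-dependent L-type calcium channel subunit alpha-1D (Rattus norvegicus), read by FLIPR (on this read-out higher numbers stand for weaker inhibition and lower numbers for stronger inhibition), the highest of the two numbers so far; compound 1 `C#CCCOC(=O)C1=C(C)NC(C)=C(C(=O)OC)C1c1cccc([N+](=O)[O-])c1` gives 35 nM. For the measured compounds named here, the one step measured at this position, a 3.3-fold higher number from compound 1 to compound 2 (0.52 log units; beyond the scatter), was modest. Compound 3 `COC(=O)C1=C(C)NC(C)=C(C(=O)OC2Cc3ccccc3C2)C1c1cccc([N+](=O)[O-])c1` differs from compound 2 by 2,3-dihydro-1H-inden-2-yl in place of 3,4-dimethoxybenzyl on an oxygen next to a carbonyl group. Going by the values given here, only that earlier step bears on the new change, and it shows a modest shift is possible in either direction, so a step of roughly that size, or none beyond the scatter, is expected in this assay. For compound 3 the expected value is 70 nM, within 20 nM to 250 nM, an expected step of a 1.7-fold lower number from compound 2 to compound 3 (0.22 log units; within the scatter).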

Compound 3, half-maximal inhibitory concentration: 43 nM
The estimate for compound 3 lay 1.6-fold (0.21 log units) above the measured number; low and high end bracket the measured number.
By their numbers in this assay, from the lowest: compounds 1 and 3 (each within the scatter of the next); then compound 2.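

The step of a 2.7-fold lower number from compound 2 to compound 3 (0.43 log units; beyond the scatter) in this assay shows that this position, on an oxygen next to a carbonyl group, can hold a group with an aromatic ring without the higher number of compound 2. The step of a 1.2-fold higher number from compound 1 to compound 3 (0.09 log units; within the scatter) leaves 2,3-dihydro-1H-inden-2-yl and but-3-yn-1-yl not told apart in this assay. No measurement offers a cause for either step. Open, going by these compounds, is whether the methoxy groups alone separate compound 2 from compound 3, which an unsubstituted benzyl would test. On these data alone, how a chain ending in an amine or a carboxylic acid would fare at this position also remains open.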